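A few compounds are considered here, and "the series" means these few. Any claim that something is new, unique, unknown or untested is made for them only; others in the source may bear on it.

In an ADME assay on Huh-7 cells (Homo sapiens) for cytotoxicity, with a stated time of 72 h (a lower number here means that less compound is tolerated, a higher number that more compound is tolerated), the three measured compounds stand as follows.

Compound 1 `CS(=O)(=O)Nc1ccc2c(c1)S(=O)(=O)N=C(c1c(O)c(-c3ccsc3)nn(CCC3CC3)c1=O)N2` gives > 1000 nM, which is a limit of the assay and not a number.
Compound 2 `CC(C)CCn1nc(CC2CCC2)c(O)c(C2=NS(=O)(=O)c3cc(NS(C)(=O)=O)ccc3N2)c1=O` gives > 33000 nM, again a limit rather than a number.
Compound 3 `CCC(C)n1nc(-c2cccs2)c(O)c(C2=NS(=O)(=O)c3cc(NS(C)(=O)=O)ccc3N2)c1=O` gives > 33000 nM, also a limit and not a number.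

Compound 3 therefore has no exact value; it sits at the limit of > 33000 nM in this assay, at which 2 of the 3 values shown sit, and the other two values shown are limits as well, one at the limit of > 1000 nM in this assay, at which 1 of the 3 values shown sits. No pair of these compounds differs in just one place, so no measured step is available, and each value simply shows that the compound was tolerated up to the concentration tested.

Compound 4 `CS(=O)(=O)Nc1ccc2c(c1)S(=O)(=O)N=C(c1c(O)c(-c3cccs3)nn(Cc3ccc(F)cc3)c1=O)N2` differs from compound 3 by 4-fluorobenzyl in place of sec-butyl on an aromatic nitrogen. The shared core and the thiophen-2-yl group stay as they are in compound 3.

With only limits to go on, no step beyond the usual scatter is expected, and the step of a number no higher from compound 3 to compound 4 (the limit leaves the size open) is an estimate that stays near the limit of compound 3. Compound 4 is expected to give about 33000 nM, with a likely range from 10000 nM to 100000 nM, and most probably the assay will again report only a limit.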

Compound 4, half-maximal cytotoxic concentration: > 1000 nM
Compound 4 ended at the assay's limit; the forecaster's own chance of this, stated with the estimate: 75%; the middle value lies beyond the limit too.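

Compound 3 and compound 4 both end at limits of the assay and not at numbers, so no step can be read between them. The compounds shown leave open whether 4-fluorobenzyl in place of sec-butyl on the aromatic nitrogen changes how much compound is tolerated in this assay, and by how much.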